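The source may hold more compounds than are shown below. What is called first, only, known or untested is meant among the compounds shown, and "the series" means these compounds.

Measured compounds in a functional assay on M14 cells (Homo sapiens) for inhibition, read by sulforhodamine B assay, with a stated time of 48 h, tested at 10 uM; a lower number here means a stronger effect, a higher number a weaker effect of the compound at the concentration tested:
- compound 1 `COc1cc(Cl)cc(-c2nn(-c3cccc(NC(=O)Nc4ccc(Cl)c(C(F)(F)F)c4)c3)cc2-c2ccncc2)c1` gives 3.99%
- compound 2 `COc1cc(Cl)cc(-c2nn(-c3cccc(NC(=O)Nc4cc(C(F)(F)F)cc(C(F)(F)F)c4)c3)cc2-c2ccncc2)c1` gives 1.22%
- compound 3 `COc1cc(Cl)cc(-c2nn(-c3cccc(NC(=O)Nc4ccc(Cl)c(Cl)c4)c3)cc2-c2ccncc2)c1` gives 18.7%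

Compound 3 stands highest of the three numbers, that is, it shows the weakest effect; compound 1 is nearest, compound 2 furthest, both beyond the scatter.

Compound 4 `COc1cc(Cl)cc(-c2nn(-c3cccc(NC(=O)Nc4cccc(C(F)(F)F)c4)c3)cc2-c2ccncc2)c1` is not yet measured. Against compound 3 the change is 3-(trifluoromethyl)phenyl in place of 3,4-dichlorophenyl on an amide-type nitrogen. Among the measured compounds shown here, one measured step bears on this: a number 14.7 percentage points higher from compound 1 to compound 3 (beyond the scatter), where exchanging a trifluoromethyl for a chloro on the urea-bound aryl raised the number by a modest margin. The change to compound 4 runs the other way, removing both chlorines and bringing in a trifluoromethyl, so the number is expected to fall rather than rise, landing nearer compound 1 than compound 3. The expected step is a number 10.7 percentage points lower from compound 3 to compound 4 (beyond the scatter). Compound 4 is therefore estimated at 8%, within 0% to 22%, because compound 1 gave 3.99% with a closely related aryl.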

Compound 4, a percentage reported as activity, at one concentration (the size of the read-out at that concentration, not a potency): 9.99%
Compound 4: middle estimate off by 2 percentage points, on the low side, within the range that was stated.
By their numbers in this assay, from the lowest: compounds 2, 1, 4 and 3 (each within the scatter of the next, the first and the last beyond it).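

On the aryl carried by the amide-type nitrogen, compound 4 shows that a second substituent can be absent without a resolved change in this assay: the steps are a number 8.8 percentage points higher from compound 2 to compound 4 (within the scatter), with hydrogen in place of trifluoromethyl, and a number 6 percentage points higher from compound 1 to compound 4 (within the scatter), with hydrogen in place of chloro. The exchange of 3,4-dichlorophenyl for 3-(trifluoromethyl)phenyl, a number 8.7 percentage points lower from compound 3 to compound 4 (within the scatter), also stays unresolved, so compound 4 cannot be separated from any of the three, although compound 2 and compound 3 lie beyond the scatter of each other. No measurement at hand explains these numbers.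

Still open, from the compounds shown here alone, is whether the plain phenyl, or an aryl bearing a carboxylic acid or a dimethylamino group, holds the same read-out. A single concentration also shows only the size of the effect at that concentration, so how these compounds would compare across a range of concentrations remains unsettled.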